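A Third Methoxy Group and Expected Cytotoxicity

The compounds below may be only part of what the source reports. "The series", "measured", "known", "first", "only" and "open" are said of these compounds alone.

Compound 1 `COc1ccc(-c2cc(/C=C/C(=O)c3ccc(N)cc3)[nH]n2)cc1` gives -67% in a functional assay on RPMI-8226 cells (Homo sapiens) for cytotoxicity, read by sulforhodamine B assay, with a stated time of 48 h, tested at 100 uM; a higher number here means a weaker effect of the compound at the concentration tested, a lower number a stronger effect. Compound 3 `COc1ccc(-c2cc(/C=C/C(=O)c3ccc(N)cc3)[nH]n2)cc1OC` carries the change methoxy in place of hydrogen on an aromatic carbon and gives -40%; the step of a number 27 percentage points higher from compound 1 to compound 3 (beyond the scatter) is modest yet beyond the scatter. Compound 2 `COc1ccc(C(=O)/C=C/c2cc(-c3cc(OC)c(OC)c(OC)c3)n[nH]2)cc1OC` rests on a different core; the difference between the two cores is not broken down here. In this assay compound 2 gives -41%, which lies within the scatter of compound 3. Compound 4 `COc1cc(C(=O)/C=C/c2cc(-c3cc(OC)c(OC)c(OC)c3)n[nH]2)cc(OC)c1OC` arises from compound 2 by methoxy in place of hydrogen on an aromatic carbon. This is the same kind of change as from compound 1 to compound 3, though here the entering group is also meta to a methoxy group. A step of similar size is expected for compound 4, a number 23 percentage points higher from compound 2 to compound 4 (beyond the scatter), because a number 27 percentage points higher from compound 1 to compound 3 (beyond the scatter) weakened the effect. Compound 4 is therefore estimated at -18%, with a likely range from -40% to 5%.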

Compound 4, a percentage reported as activity, at one concentration (the size of the read-out at that concentration, not a potency): -26%
The estimate for compound 4 lay 8 percentage points above the measured number; the range from low to high includes it.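

In this assay, methoxy in place of hydrogen on an aromatic carbon gives a number 15 percentage points higher from compound 2 to compound 4 (beyond the scatter), so on this second core the change again goes towards a weaker effect. The size of the step also carries over within the scatter, as the two steps side by side show: the same change on two cores in this assay, a number 27 percentage points higher (beyond the scatter) from compound 1 to compound 3 and a number 15 percentage points higher (beyond the scatter) from compound 2 to compound 4, 12 percentage points apart, within the scatter of two such steps. This supports carrying the change between these two cores in direction and rough size, but two pairs do not show that it would hold on any other core, and they do not explain why the number rises.

Within the data shown here, the only group seen entering here is methoxy, so whether ethoxy or a chlorine atom in the same place would shift the number in the same way remains open. These numbers also come from a single concentration, so they show only a stronger or weaker effect at that concentration.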